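The compounds below may be only part of what the source reports. "The series", "measured", "known", "first", "only" and "open" are said of these compounds alone.

Three compounds share one core, and a fourth, compound 4 `Cc1ccc(-n2ccnc2SCC(=O)Nc2ccccc2C)cc1`, still awaits its number. Going by the values given here, compound 2 `Cc1ccccc1NC(=O)CSc1nccn1-c1ccc(Cl)cc1` is the only one with a measured value: in an ADME assay on MT4 cells (Homo sapiens) for cytotoxicity, read by MTT assay (on this read-out lower numbers stand for higher toxicity in this test and higher numbers for lower toxicity in this test), compound 2 gives 160000 nM. Compound 1 `COc1ccc(-n2ccnc2SCC(=O)Nc2ccccc2C)cc1` reaches only a limit of the assay, > 353000 nM. Compound 3 `O=C(CSc1nccn1-c1ccc(Cl)cc1)Nc1ccccc1Br` likewise gives only a limit, > 300000 nM. Compound 4 differs from compound 2 by methyl in place of chloro on an aromatic carbon. The step that matters here is an at least 2.2-fold lower number from compound 1 to compound 2 (0.34 log units; beyond the scatter); it altered that same place. The step of an at least 1.8-fold higher number from compound 2 to compound 3 (0.27 log units; that floor lies within the scatter) concerns another part of the molecule. The expected step is a 1.9-fold higher number from compound 2 to compound 4 (0.27 log units; within the scatter), a modestly higher number, possibly again only a limit. Compound 4 is therefore expected at 300000 nM, with a range from 130000 nM to 650000 nM.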

Compound 4, half-maximal cytotoxic concentration: 147000 nM
Estimate against measurement, compound 4: 2.0-fold (0.31 log units) above; the measured number falls inside the stated range.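

Going from 4-chlorophenyl to 4-methylphenyl gives a 1.1-fold lower number from compound 2 to compound 4 (0.04 log units; within the scatter), so in this assay chloro and methyl read alike at this position. Methoxy stands apart from both groups, with an at least 2.4-fold lower number from compound 1 to compound 4 (0.38 log units; beyond the scatter), in the same direction as the step from methoxy to chloro. The methoxy side of both steps is only a limit, that of compound 1: the limit of > 353000 nM in this assay, at which 1 of the 4 values shown sits. The compounds shown leave open how an amine, a carboxylic acid or a longer chain would read at this position. From the compounds shown here alone, how far compound 1 truly lies from compound 4 also stays open.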